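The source may hold more compounds than are shown below. What is called first, only, known or untested is meant among the compounds shown, and "the series" means these compounds.

compound 1 `CC1(C)[C@H]2CC[C@]1(C)N(Cc1cn(-c3ccccc3Br)nn1)C(=O)C2` gives 500 nM
compound 2 `CC1(C)[C@H]2CC[C@]1(C)N(Cc1cn(-c3cccc(O)c3)nn1)C(=O)C2` gives 270 nM
compound 3 `CC1(C)[C@H]2CC[C@]1(C)N(Cc1cn(-c3cccc(Br)c3)nn1)C(=O)C2` gives 120 nM

All three compounds were tested in a functional assay on SGC-7901 cells (Homo sapiens) for inhibition, read by MTT assay, with a stated time of 24 h (a higher number here means a weaker inhibitor, a lower number a stronger inhibitor), and differ only in the substituted phenyl group on the shared core. Compound 3, with 120 nM as its value, stands lowest of the three, and its steps to both others lie beyond the scatter.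

Compound 4 `COc1cccc(-n2cc(CN3C(=O)C[C@@H]4CC[C@@]3(C)C4(C)C)nn2)c1` has methoxy in place of bromo on an aromatic carbon, meta to a large group (methoxy in place of bromo on an aromatic carbon). The closest guide is the other swap at that place, which gave a 2.3-fold lower number from compound 2 to compound 3 (0.35 log units; beyond the scatter) when bromo replaced hydroxy. Two further steps say less, as both start from the 2-bromophenyl compound and neither involves methoxy: a 4.2-fold lower number from compound 1 to compound 3 (0.62 log units; beyond the scatter) for 3-bromophenyl, and a 1.9-fold lower number from compound 1 to compound 2 (0.27 log units; within the scatter) for 3-hydroxyphenyl.

Among the compounds with values here, no methoxy compound has been measured, so the size of this step remains uncertain. Within the data shown here, compound 2, the only compound with a group other than bromo at that place, gives 270 nM and so points to a small rise in this assay of about that size or less, not clearly beyond the scatter. The estimated step is a 1.8-fold higher number from compound 3 to compound 4 (0.26 log units; within the scatter) and nothing larger is expected. For compound 4 the estimated value is 220 nM with between 90 nM and 550 nM as the expected range.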

Compound 4, half-maximal inhibitory concentration: 590 nM
Beside the measured number, compound 4's estimate is 2.7-fold (0.43 log units) below it, outside the stated range (above it).
By their numbers in this assay, from the lowest: compound 3; then compounds 2, 1 and 4 (each within the scatter of the next, the first and the last beyond it).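

In this assay, the change at this aromatic carbon brings a 4.9-fold higher number from compound 3 to compound 4 (0.69 log units; beyond the scatter), so in this series bromo cannot be exchanged for methoxy without a clear rise in the number, which means a weaker inhibitor. The oxygen-bearing pair adds a second point: putting a methyl on the oxygen of the hydroxy group gives a 2.2-fold higher number from compound 2 to compound 4 (0.34 log units; beyond the scatter), so the hydroxy and methoxy compounds are also distinct in this assay, although they differ only by that methyl. Compound 4 and the 2-bromophenyl compound cannot be told apart, with a 1.2-fold higher number from compound 1 to compound 4 (0.07 log units; within the scatter), so the 3-methoxyphenyl group and the 2-bromophenyl group give numbers within the scatter of each other.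

Still open, on these data alone, is how other groups at this place would compare with bromo in compound 3 at 120 nM, for example chloro, an amine, a carboxylic acid or a longer chain such as ethoxy. The measurements shown also offer no established explanation for the differences among bromo, hydroxy and methoxy at this place.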